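Replacing methylcarbamoyl with trifluoromethyl in compound 2

This account rests on a few compounds, and the source may have more. Where it says the series, first, only, none or still open, it means among the compounds named here.

In a physicochemical assay for lipophilicity, at pH 7.4 (a lower number here means a more polar compound, a higher number a more lipophilic compound), compound 2 (`CNC(=O)c1cc(N)c(Nc2ccc(C#N)cc2)cc1Oc1c(C)cc(CCC#N)cc1C`) gives 2.65, the lower of the two numbers, and compound 1 (`Cc1cc(/C=C/C#N)cc(C)c1Oc1cc(Nc2ccc(C#N)cc2)c(N)cc1C(N)=O`) gives 3.53. Compound 3 (`Cc1cc(/C=C/C#N)cc(C)c1Oc1cc(Nc2ccc(C#N)cc2)c(N)cc1[N+](=O)[O-]`) gives only a limit, > 5. Compound 4 (`Cc1cc(CCC#N)cc(C)c1Oc1cc(Nc2ccc(C#N)cc2)c(N)cc1C(F)(F)F`) differs from compound 2 by trifluoromethyl in place of methylcarbamoyl on an aromatic carbon. For the measured compounds named here, the one measured step that bears on this change also removes an amide group from that carbon: nitro in place of carbamoyl, a number at least 1.47 log units higher from compound 1 to compound 3 (beyond the scatter). From the compounds shown here alone, its true size is unknown, as it ends at the limit of > 5 in this assay, at which 1 of the 3 values shown sits. A similar large rise in this assay is therefore expected, and the expected step is a number 1.85 log units higher from compound 2 to compound 4 (beyond the scatter). The estimated value for compound 4 is 4.5, with a range of 3.9 to 5.1.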

Compound 4, partition coefficient: > 5
Compound 4: no number, only a limit (the forecaster's own chance of this, stated with the estimate: 25%); middle value at least 0.50 log units away from the limit.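

In this assay, trifluoromethyl in place of methylcarbamoyl on this aromatic carbon gives a number at least 2.35 log units higher from compound 2 to compound 4 (beyond the scatter). Compound 4 gives only a limit, > 5. Losing the amide at this position thus raises the number on a second side chain and from a methylcarbamoyl start, not only in a number at least 1.47 log units higher from compound 1 to compound 3 (beyond the scatter), and this second replacement also ends at the top of the range: the limit of > 5 in this assay, at which 2 of the 4 values shown sit.

The true size of both steps cannot be read. From the compounds shown here alone, whether a carboxylic acid or an aminomethyl group on this carbon would give a number within range remains open.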